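Fluoro for hydrogen: from compound 2 toward compound 4

The source may report more compounds than this note shows. Statements on the series, on what has been measured and on what is new or still open speak of the compounds shown alone.

Of the compounds shown here, three sharing one core have been measured in an assay on isolated protein for binding affinity to 5-hydroxytryptamine receptor 6 (Homo sapiens), tested at 10 uM; on this read-out lower numbers stand for less inhibition and higher numbers for more inhibition at the one concentration tested (going by the name of the read-out). Going by the values given here, compound 1 `CC(C)Cc1cc(CNS(=O)(=O)c2ccc3ccccc3c2)nn1-c1ccccc1` gives 67.8%, and compound 3 `Cc1c(Cl)cccc1S(=O)(=O)NCc1cc(CC(C)C)n(-c2ccccc2)n1` gives 72.3%; the step of a number 4.5 percentage points higher from compound 1 to compound 3 (within the scatter) is the only one-place step among the measured compounds, and it lies within the scatter. Compound 2 `CC(C)Cc1cc(CNS(=O)(=O)Cc2cccc3ccccc23)nn1-c1ccccc1` gives 28.7%, the lowest of the three numbers: compound 1 is nearest to it, compound 3 furthest, and both gaps lie beyond the scatter.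

Compound 4 `CC(C)Cc1cc(CNS(=O)(=O)Cc2cccc3ccccc23)nn1-c1ccc(F)cc1` differs from compound 2 in one place: fluoro in place of hydrogen on an aromatic carbon. The same difference, cut one bond further out, reads phenyl to 4-fluorophenyl.

Among the compounds with values here, no measured step bears on this change. The one step shown, from compound 1 to compound 3, alters the group on the sulfonyl sulfur, not the ring that carries the fluoro, and it stayed within the scatter. Nothing in the measured numbers points in either direction for a fluoro in place of hydrogen on this ring, so no step beyond the scatter is expected.

Compound 4 is therefore estimated to give 30%, with a range from 15% to 47%. The expected step is a number 1.3 percentage points higher from compound 2 to compound 4 (within the scatter), taken as no change beyond the scatter.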

Compound 4, a percentage reported as inhibition, at one concentration (the size of the read-out at that concentration, not a potency): 36.1%
For compound 4 the middle estimate is 6.1 percentage points below the measured one; the range from low to high includes it.
By their numbers in this assay, from the lowest: compounds 2 and 4 (each within the scatter of the next); then compounds 1 and 3 (each within the scatter of the next).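

In this assay, going by these compounds alone, the change from phenyl to 4-fluorophenyl gives a number 7.4 percentage points higher from compound 2 to compound 4 (within the scatter) and is the first measured step on this ring, since the only earlier step altered the group on the sulfonyl sulfur. In this single pair, a fluoro para to a large group therefore leaves the read-out without a change beyond the scatter, so this position accepts one small added atom with no readable effect on inhibition at the one concentration tested. No supporting data accompany this step, so nothing can be said about what lies behind the result.

Within the data shown here, it remains open whether the same replacement would also stay within the scatter on compound 1 or compound 3, whose sulfonyl groups differ from the one carried by compound 2 and compound 4. On these data alone, it is also open whether a group larger than fluoro or of another kind at the same ring position, such as methoxy, an amine or a carboxylic acid, would move the number beyond the scatter in either direction.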